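The compounds below may be only part of what the source reports. "The series", "measured", "known", "first", "only" and "open" are said of these compounds alone.

Measured in a functional assay on A2780 cells (Homo sapiens) for inhibition; on this read-out lower numbers stand for stronger inhibition and higher numbers for weaker inhibition:
compound 1 `CC(C(=O)Nc1cc(C2CC2)[nH]n1)c1ccc(N2C(=O)CCC2C)cc1`: 6400 nM
compound 2 `C[C@H](C(=O)Nc1cc(C2CC2)[nH]n1)c1ccc(N2Cc3ccccc3C2=O)cc1`: 1020 nM
compound 3 `CC(C(=O)Nc1cc(C2CC2)[nH]n1)c1ccc(N2C(=O)CCC2c2ccccc2)cc1`: 15300 nM

Compound 1 holds the second highest of the three numbers, with compound 3 higher and compound 2 lower. Next is compound 4 `CC(C(=O)Nc1cc(C2CC2)[nH]n1)c1ccc(N2CCNC2=O)cc1`, not yet measured. The change is a group of 6 heavy atoms (3 carbon, 2 nitrogen, 1 oxygen; one five-membered non-aromatic ring with 2 hetero atoms) in place of a group of 7 heavy atoms (5 carbon, 1 nitrogen, 1 oxygen; one five-membered non-aromatic ring with 1 hetero atom), on an aromatic carbon, with 2-oxoimidazolidin-1-yl entering para to a large group. For the measured compounds named here, the one measured step at this ring, a 2.4-fold higher number from compound 1 to compound 3 (0.38 log units; beyond the scatter), is modest and is a different change, phenyl in place of methyl, so it is only a weak guide. No step beyond the scatter is therefore expected in this assay, and no direction is favoured. The expected change is a 1.1-fold lower number from compound 1 to compound 4 (0.03 log units; within the scatter). Compound 4 is estimated at 6000 nM, with an expected range of 2000 nM to 18000 nM.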

Compound 4, half-maximal inhibitory concentration: 2250 nM
The estimate for compound 4 lay 2.7-fold (0.43 log units) above the measured number; measured number inside the range.
By their numbers in this assay, from the lowest: compound 2; then compound 4; then compound 1; then compound 3.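

With 2-oxoimidazolidin-1-yl on the aromatic carbon, this assay shows a 2.8-fold lower number from compound 1 to compound 4 (0.45 log units; beyond the scatter). The earlier step at this place, a 2.4-fold higher number from compound 1 to compound 3 (0.38 log units; beyond the scatter), went the other way, so changes here can move the number in either direction, and changing the ring itself can lower it. The entering group carries a hydrogen-bond donor that the leaving group lacks, but nothing measured bears on the reason for the step.

Still open, as far as these compounds go, is whether that donor matters: a methyl group on the ring nitrogen would test this, and an open-chain urea or morpholine at the same place would test the need for this ring.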